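A few compounds are considered here, and "the series" means these few. Any claim that something is new, unique, unknown or untested is made for them only; others in the source may bear on it.

Of the compounds shown here, three have been measured in a functional assay on HepG2 cells (Homo sapiens) for inhibition, read by MTT assay, with a stated time of 48 h; on this read-out higher numbers stand for weaker inhibition and lower numbers for stronger inhibition. Compound 1, `C[Se]c1ccc(N(C)c2nc(C3CC3)nc3ccccc23)cc1`, gives 32 nM. Compound 2, `C[Se]c1ccc(N(C)c2nc(C)nc3ccccc23)cc1C`, gives 6 nM. Compound 3, `COc1ccc(N(C)c2nc(C)nc3ccccc23)cc1OCCCCC[Se]C#N`, gives 5210 nM, the highest of the three numbers, and its gaps to compound 1 and to compound 2 both lie well beyond the usual scatter, so compound 3 is clearly the weakest inhibitor here.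

Compound 4, `COc1ccc(N(C)c2nc(C)nc3ccccc23)cc1C[Se]C#N`, has not yet been measured. It differs from compound 3 in one place: a group of 4 heavy atoms (2 carbon, 1 nitrogen, 1 selenium; no ring) in place of a group of 9 heavy atoms (6 carbon, 1 nitrogen, 1 oxygen, 1 selenium; no ring), on an aromatic carbon. Among the compounds with values here, no measured pair shows such a change, so there is no step to lean on. The expectation is a moderate move toward a lower number, a 3.5-fold lower number from compound 3 to compound 4 (0.54 log units; beyond the scatter), in this assay. Compound 4 is therefore estimated at 1500 nM, within a range from 300 nM to 8000 nM.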

Compound 4, half-maximal inhibitory concentration: 1110 nM
Compound 4: the middle estimate sits 1.4-fold (0.13 log units) above what was measured; measured number inside the range.
By their numbers in this assay, from the lowest: compound 2; then compound 1; then compound 4; then compound 3.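

In this assay, placing the group of 4 heavy atoms instead of the group of 9 heavy atoms on this aromatic carbon, ortho to a methoxy group, gives a 4.7-fold lower number from compound 3 to compound 4 (0.67 log units; beyond the scatter). Within the data shown here, this is the first direct reading at this position: both groups carry selenium and a nitrile, and the smaller group gives the lower number in this pair. No measurement here accounts for the difference. Going by these compounds, it remains open how a chain of intermediate length, or an amine in the same place, would read, and whether this step would hold on another core.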